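A few compounds are considered here, and "the series" means these few. Any claim that something is new, unique, unknown or untested is made for them only; others in the source may bear on it.

Notes on the series. In a functional assay (plasma) with Oryctolagus cuniculus as the target (a higher number here means a weaker inhibitor, a lower number a stronger inhibitor), compound 1 (`Cc1nc2cnccc2n1CC1CCN(C(=O)CC(C)(C)c2ccccc2)CC1`) gives 6.7 nM and compound 2 (`Cc1nc2cnccc2n1CC1CCN(C(=O)CC(C)(O)c2ccccc2)CC1`) gives 6.9 nM, so compound 2 stands level with compound 1, within the scatter. Compound 3 (`COc1ccccc1N(C)CC(=O)N1CCC(Cn2c(C)nc3cnccc32)CC1`) carries a larger change on the saturated chain carbon bound to a carbonyl carbon: (2-methoxyphenyl)(methyl)amino in place of 1-hydroxy-1-phenylethyl on a saturated chain carbon bound to a carbonyl carbon. Going by the values given here, only one measured step bears on it, a 1.0-fold higher number from compound 1 to compound 2 (0.01 log units; within the scatter), and that step exchanged hydroxy for methyl within the group that now leaves. It stayed within the scatter, but it does not cover loss of the whole group or entry of the (2-methoxyphenyl)(methyl)amino group. The data therefore give only weak guidance, and a moderate rise in the number is expected, a 2.2-fold higher number from compound 2 to compound 3 (0.34 log units; beyond the scatter). For compound 3 the estimated value is 15 nM, with an expected range of 4 nM to 60 nM.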

Compound 3, half-maximal inhibitory concentration: 14 nM
Compound 3: middle estimate off by 1.1-fold (0.03 log units), on the high side; low and high end bracket the measured number.
By their numbers in this assay, from the lowest: compounds 1 and 2 (each within the scatter of the next); then compound 3.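

In this assay, (2-methoxyphenyl)(methyl)amino in place of 1-hydroxy-1-phenylethyl on the saturated chain carbon bound to a carbonyl carbon gives a 2.0-fold higher number from compound 2 to compound 3 (0.31 log units; beyond the scatter), and in place of 1-methyl-1-phenylethyl it gives a 2.1-fold higher number from compound 1 to compound 3 (0.32 log units; beyond the scatter). This position therefore responds to exchange of the whole group, where the hydroxy-for-methyl exchange stayed within the scatter, yet both steps are only modest, so a quite different group is accepted here with a limited loss. No accompanying measurement bears on this result, and the rise cannot be tied to any feature of the new group.

The methoxy, the N-methyl and the amino nitrogen enter together, so their separate contributions stay unresolved. Going by these compounds, how a plain phenylamino group, a carboxylic acid or a longer alkyl chain would read at this place also remains open.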